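Methoxy for methylsulfanyl on the nitroaryl ether of compound 3

The source may report more compounds than this note shows. Statements on the series, on what has been measured and on what is new or still open speak of the compounds shown alone.

Series notes. Compound 3 `CSc1ccc(OC(C)(C)C2OCC(C/C=C\CCC(=O)O)C(c3cccnc3)O2)c([N+](=O)[O-])c1` gives the lowest number of the three measured, 4.47 nM in a functional assay for inhibition, with Homo sapiens as the target; on this read-out lower numbers stand for tighter binding and higher numbers for weaker binding. Going by the values given here, compound 2 `N#Cc1ccccc1C1OCC(C/C=C\CCC(=O)O)C(c2cccnc2)O1` gives 245 nM and compound 1 `N#Cc1ccc(C2OCC(C/C=C\CCC(=O)O)C(c3cccnc3)O2)cc1` gives 1290 nM in this assay; the only step measured, a 5.3-fold lower number from compound 1 to compound 2 (0.72 log units; beyond the scatter), concerns the cyanophenyl group on a saturated ring carbon and not the aromatic ring carrying the nitro group. Compound 4 `COc1ccc(OC(C)(C)C2OCC(C/C=C\CCC(=O)O)C(c3cccnc3)O2)c([N+](=O)[O-])c1` differs from compound 3 by methoxy in place of methylsulfanyl on an aromatic carbon. Among the compounds with values here, no measured step touches this position, so no size can be read off from the measured compounds; what is known is only that the leaving and entering groups match in the counts given. The expectation is therefore a step no larger than modest in this assay, direction uncertain, with a slight lean toward a higher number. Compound 4 is expected to give 7 nM in this assay, between 2 nM and 25 nM. This corresponds to an expected step of a 1.6-fold higher number from compound 3 to compound 4 (0.19 log units; within the scatter).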

Compound 4, dissociation constant: 6.17 nM
For compound 4 the middle estimate is 1.1-fold (0.05 log units) above the measured one; low and high end bracket the measured number.
By their numbers in this assay, from the lowest: compounds 3 and 4 (each within the scatter of the next); then compound 2; then compound 1.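

Methoxy and methylsulfanyl on this aromatic carbon, meta to a nitro group and para to a large group, cannot be told apart in this assay: the exchange gives a 1.4-fold higher number from compound 3 to compound 4 (0.14 log units; within the scatter). Going by these compounds alone, this is the first measured step at this position, and it shows that the low number of compound 3 does not depend on the sulfur atom, since the oxygen counterpart, compound 4, stands level with it. Nothing available offers an explanation for this result.

The compounds shown leave open how far this position accepts groups other than these two, for example an amine, a carboxylic acid or a longer chain such as butoxy. They also leave open what the nitro group itself contributes to the numbers of compound 3 and compound 4.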